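Aryl swap on the hydrazone of compound 3

The source may report more compounds than this note shows. Statements on the series, on what has been measured and on what is new or still open speak of the compounds shown alone.

Compound 1 `COc1ccc(/C=N/NC(=O)Nc2ccc(Oc3ccnc4cc(OCCCN5CCCCC5)c(OC)cc34)c(F)c2)cc1`: 126000 nM in an ADME assay on PBL cells (Homo sapiens) for cytotoxicity, read by MTT assay, with a stated time of 72 h; a lower number here means a stronger inhibitor, a higher number a weaker inhibitor
Compound 3 `COc1ccc(/C=N/NC(=O)Nc2ccc(Oc3ccnc4cc(OCCCN5CCC(C)CC5)c(OC)cc34)c(F)c2)cc1`: 23000 nM in this assay
Compound 2 `COc1cc2c(Oc3ccc(NC(=O)N/N=C/c4ccncc4)cc3F)ccnc2cc1OCCCN1CCCCC1`: "not determined" (no result reported) in this assay

Among the measured compounds shown here, compound 3 gives the lowest of the two numbers in this assay; the only measured step, a 5.5-fold lower number from compound 1 to compound 3 (0.74 log units; beyond the scatter), goes with a methyl in place of hydrogen on a saturated ring carbon. Compound 4 `COc1cc2c(Oc3ccc(NC(=O)N/N=C/c4ccc(F)cc4Cl)cc3F)ccnc2cc1OCCCN1CCC(C)CC1` keeps that methyl and differs from compound 3 only in 2-chloro-4-fluorophenyl in place of 4-methoxyphenyl on a carbon with a double bond to nitrogen. For the measured compounds named here, no measured step touches this hydrazone carbon, so the step from compound 1 to compound 3 does not bear on the aryl exchange. Compound 4 is therefore expected to show no change at the digits printed from compound 3 to compound 4 (within the scatter), nothing beyond the scatter. The estimate for compound 4 in this assay is 23000 nM, within 8000 nM to 70000 nM.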

Compound 4, half-maximal inhibitory concentration: 79500 nM
The estimate for compound 4 lay 3.5-fold (0.54 log units) below the measured number; the whole stated range lies below it.
By their numbers in this assay, from the lowest: compound 3; then compounds 4 and 1 (each within the scatter of the next).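

In this assay, among the compounds shown here, the aryl group on a carbon with a double bond to nitrogen proves able to shift the number: 2-chloro-4-fluorophenyl in place of 4-methoxyphenyl gives a 3.5-fold higher number from compound 3 to compound 4 (0.54 log units; beyond the scatter) and thus a change at a place no earlier step had touched. For the compounds shown here, this step runs upward, whereas the only earlier step, the methyl on a saturated ring carbon, ran downward. No measured evidence accounts for the step.

From the compounds shown here alone, whether the chlorine, the fluorine or the loss of the methoxy group carries the step remains open. So does how an unsubstituted phenyl or a 4-aminophenyl group would read on this carbon.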